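A few compounds are considered here, and "the series" means these few. Any claim that something is new, unique, unknown or untested is made for them only; others in the source may bear on it.

Working notes on the diacylhydrazine set. In an assay on cells for agonist activity at ecdysone receptor (Bombyx mori), read by a luciferase reporter, with a stated time of 24 h (on this read-out lower numbers stand for an effect already at smaller amounts and higher numbers for an effect only at larger amounts of compound), compound 3 `CCc1ccc(C(=O)NN(C(=O)CCC(C)C)C(C)(C)C)cc1` gives 832 nM, the lowest of the three numbers in hand. Compound 2 `CCCCCC(=O)N(NC(=O)c1ccc(CC)cc1)C(C)(C)C` gives 2820 nM, and compound 1 `CC(C)(C)N(NC(=O)c1ccccc1)C(=O)C1CCCCC1` gives 46800 nM, so compound 3 stands apart from both by steps beyond the scatter.

The next compound is compound 4 `CCc1ccc(C(=O)NN(C(=O)C2CCCCC2)C(C)(C)C)cc1`, reached from compound 3 by the change (cyclohexyl in place of isopentyl on a carbonyl carbon).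

For the measured compounds named here, only one measured step bears on this position: a 3.4-fold lower number from compound 2 to compound 3 (0.53 log units; beyond the scatter), a gain from branching the chain on the carbonyl attached to the amide-type nitrogen. Going by the values given here, no measured pair isolates the move from an open chain to a six-membered carbon ring at this carbonyl. Compound 1 also carries cyclohexyl at this carbonyl, but it differs from compound 4 in a second place as well. Among the compounds with values here, the value of compound 1, 46800 nM, set against compound 3 shows only that the pair is far apart, not what the ring alone does.

Within the data shown here, with the branched chain already the best of the measured set and no direct precedent for the ring, the expectation for compound 4 is a small shift toward higher numbers, a 1.8-fold higher number from compound 3 to compound 4 (0.26 log units; within the scatter), within a wide band. Compound 4 is estimated at 1500 nM, range 400 nM to 6000 nM.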

Compound 4, half-maximal effective concentration: 9330 nM
For compound 4 the middle estimate is 6.2-fold (0.79 log units) below the measured one, and the stated range ends below it.
By their numbers in this assay, from the lowest: compound 3; then compound 2; then compound 4; then compound 1.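

In this assay the move from an open chain to the ring at this carbonyl can now be read on its own: cyclohexyl in place of isopentyl gives an 11-fold higher number from compound 3 to compound 4 (1.05 log units; beyond the scatter) and cyclohexyl in place of pentyl gives a 3.3-fold higher number from compound 2 to compound 4 (0.52 log units; beyond the scatter) and so, with the rest of the molecule held fixed, both open chains stand at lower numbers than the ring. The set also gains its first reading of the aromatic substituent, with cyclohexyl held on the carbonyl carbon: ethyl in place of hydrogen on an aromatic carbon gives a 5.0-fold lower number from compound 1 to compound 4 (0.70 log units; beyond the scatter) and thus accounts for part of the wide gap seen earlier between compound 1 and the other compounds. No measurement at hand accounts for the size of any of these steps.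

Going by these compounds, whether the higher number follows the six-membered ring as such or its direct attachment to the carbonyl carbon stays open, and a cyclopentyl ring or a cyclohexylmethyl group at this carbonyl would separate the two readings. On these data alone, it also stays open whether the ethyl step carries over to the open chains, which would need an isopentyl or pentyl compound with hydrogen in place of ethyl on the aromatic carbon.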